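The source may hold more compounds than are shown below. What is called first, only, known or untested is meant among the compounds shown, and "the series" means these compounds.

Measured compounds:
compound 1 `C=CC(=C)CC[C@@H]1[C@@]2(C)CCC[C@](C)(COC(=O)/C=C\c3ccc(O)cc3)[C@@H]2CC[C@@]1(C)O`: 14100 nM
compound 2 `C=C[C@@](C)(O)CC[C@H]1C(=C)CC[C@@H]2[C@]1(C)CCC[C@]2(C)C(=O)O`: > 40000 nM

Among the compounds with values here, in a functional assay on HL-60 cells (Homo sapiens) for cytotoxicity, read by MTT assay, with a stated time of 48 h (a lower number here means a stronger inhibitor, a higher number a weaker inhibitor), compound 1 gives 14100 nM, the only numerical value among the two. For compound 2 this assay returns only a limit, > 40000 nM, not a number; it sits at the limit of > 40000 nM in this assay, at which 1 of the 2 values shown sits. Compound 3 `C=CC(=C)CC[C@@H]1[C@@]2(C)CCC[C@](C)(COC(=O)/C=C\c3ccc(O)c(OC)c3)[C@@H]2CC[C@@]1(C)O` keeps the core of compound 1 and its ester, and differs only by methoxy in place of hydrogen on an aromatic carbon. Within the data shown here, no step between measured compounds is available, so the change is expected to move the value no further than the scatter. Compound 3 is estimated at 12000 nM, within 5000 nM to 30000 nM, meaning an expected step of a 1.2-fold lower number from compound 1 to compound 3 (0.07 log units; within the scatter).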

Compound 3, half-maximal inhibitory concentration: 9100 nM
For compound 3 the middle estimate is 1.3-fold (0.12 log units) above the measured one, within the range that was stated.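

Methoxy in place of hydrogen on an aromatic carbon, ortho to a hydroxy group, gives a 1.5-fold lower number from compound 1 to compound 3 (0.19 log units; within the scatter) in this assay, so this position takes the added group without a change that can be told from the scatter. No measurement shown gives a cause for this step. Going by these compounds, what stays open is whether another group at this position, such as an amine or a carboxylic acid, would move the value beyond the scatter, and whether replacing the hydroxy group itself would do so.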